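The source may report more compounds than this note shows. Statements on the series, on what has been measured and on what is new or still open speak of the compounds shown alone.

Measured so far in an ADME assay on microsomes from liver (Mus musculus) for metabolic stability, with a stated time of 30 min; a higher number here means that more of the compound is left, a lower number that less of the compound is left:
compound 1 `CCn1c(=O)/c(=C2\Sc3cc(F)ccc3N2C)s/c1=C\c1ccccn1` gives 5%
compound 2 `CCn1c(=O)/c(=C2\Sc3c(F)cccc3N2C)s/c1=C\c1ccccn1` gives 12%
compound 3 `CCn1c(=O)/c(=C2\Sc3c(Cl)cccc3N2C)s/c1=C\c1ccccn1` gives 17%

Compound 2 sits in the middle of the three numbers in this assay. Toward compound 3 the gap is a number 5 percentage points higher from compound 2 to compound 3 (within the scatter), which is the change chloro in place of fluoro on an aromatic carbon. Toward compound 1 the gap is of similar size, and both gaps stay within the usual scatter, so the three measured compounds are not separated from one another here.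

Compound 4 `CCn1c(=O)/c(=C2\Sc3c(F)cccc3N2C)s/c1=C\c1ccncc1` differs from compound 2 by pyridin-4-yl in place of pyridin-2-yl on a double-bonded chain carbon bound to an aromatic carbon. Among the measured compounds shown here, no measured step touches the ring on the double-bonded chain carbon; the only measured step, from compound 2 to compound 3, concerns the halogen on the aromatic ring of the shared core and stays within the scatter. Nothing in the measured series therefore points to a change beyond the scatter for compound 4 in this assay, and the expectation is a number close to that of compound 2.

Compound 4 is expected to give about 12% in this assay, with a range from 4% to 25%. The expected step of no change at the digits printed from compound 2 to compound 4 (within the scatter) lies within the usual scatter.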

Compound 4, percent of the compound remaining: 30%
Estimate against measurement, compound 4: 18 percentage points below; measured number outside the range, above it.
By their numbers in this assay, from the lowest: compounds 1, 2 and 3 (each within the scatter of the next, the first and the last beyond it); then compound 4.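

In this assay, among the compounds shown here, pyridin-4-yl in place of pyridin-2-yl on a double-bonded chain carbon bound to an aromatic carbon gives a number 18 percentage points higher from compound 2 to compound 4 (beyond the scatter) and is the first single change to clear the scatter. For the compounds shown here, the two groups have the same atoms and the same printed counts, so the read-out here differs with how the ring is joined, whereas the only earlier step, a number 5 percentage points higher from compound 2 to compound 3 (within the scatter) on the halogen of the shared core, did not separate its compounds. Nothing available bears on the reason for this step.

Going by these compounds, whether pyridin-3-yl or plain phenyl at this carbon would give a number closer to compound 2 or to compound 4 remains open. Also open, on these data alone, is whether pyridin-4-yl has a similar effect on the cores of compound 1 and compound 3.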